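The source may report more compounds than this note shows. Statements on the series, on what has been measured and on what is new or still open speak of the compounds shown alone.

Three compounds built on one shared core are compared here: compound 1 (`CCCCCCCCOc1nc(N)nc2c1ncn2/C=C1/CC1(CO)CO`), compound 2 (`CN(C)c1nc(N)nc2c1ncn2/C=C1/CC1(CO)CO`) and compound 3 (`Nc1nc(OCc2ccccc2)c2ncn(/C=C3/CC3(CO)CO)c2n1`). In an ADME assay on MOLT-3 cells (Homo sapiens) for cytotoxicity, with a stated time of 7 days (a lower number here means that less compound is tolerated, a higher number that more compound is tolerated), compound 2 has no number to stand on, since its entry reads "not determined" (no result reported) and gives no starting point. In this assay compound 1 gives > 20000 nM as its result, which is a limit of the assay and not a number. The structural change is benzyloxy in place of dimethylamino on an aromatic carbon and puts benzyloxy in place of dimethylamino on an aromatic carbon. Among the measured compounds shown here, no measured step connects these compounds, so the size of this change cannot be read from the data. For the measured compounds named here, the expectation is a step within the usual scatter, in neither direction, resting only on compound 1 and the limit of > 20000 nM in this assay, at which 1 of the 2 values shown sits, as the sole guide. Compound 3 is expected to give a half-maximal cytotoxic concentration near 25000 nM within an estimated range from 8000 nM to 60000 nM and is expected quite possibly to give only a limit.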

Compound 3, half-maximal cytotoxic concentration: > 20000 nM
Compound 3 ended at the assay's limit; the forecaster's own chance of this, stated with the estimate: 70%; the middle value is on the limit's open side.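

Compound 1 and compound 3 both end at a limit of this assay and not at a number, so no step between them can be read: the limit of > 20000 nM in this assay, at which 2 of the 3 values shown sit.

On these data alone, what stays open is the true size of the values for compound 1 and compound 3, and where compound 2 stands in this assay.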